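Replacing a large ether substituent with isobutyl on the shared core

This account rests on a few compounds, and the source may have more. Where it says the series, first, only, none or still open, it means among the compounds named here.

Measured in a functional assay on HEK293 cells for agonist activity at G-protein coupled receptor 39 (Homo sapiens), read by scintillation proximity assay and inositol phosphate accumulation, with a stated time of 75 min, in the presence of a further agent that is not named here; on this read-out higher numbers stand for an effect only at larger amounts of compound and lower numbers for an effect already at smaller amounts:
Compound 1 `Cc1nn(-c2ncnc3nc[nH]c23)c2c1C(OCc1cc(F)cc3c1OCOC3)CC(=O)N2`: 1.5 nM
Compound 2 `Cc1nn(-c2ncnc3nc[nH]c23)c2c1C(c1ccc(F)cc1Cl)CC(=O)N2`: 9 nM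
Compound 3 `Cc1nn(-c2ncnc3nc[nH]c23)c2c1C(NC(=O)Cc1cccs1)CC(=O)N2`: 3 nM

Among these three, compound 1 gives the lowest number. Its nearest neighbour is compound 3, whose value sits within the usual scatter of the value of compound 1, so no order can be claimed between those two; compound 2 lies beyond the scatter from compound 1. For the measured compounds named here, the only step measured in one place, a 3.0-fold lower number from compound 2 to compound 3 (0.48 log units; beyond the scatter), concerns a different position on the shared core, where an aryl group was swapped for an amide-linked group, and its size was modest.

Compound 4 `Cc1nn(-c2ncnc3nc[nH]c23)c2c1C(OCC(C)C)CC(=O)N2` differs from compound 1 at the ether side chain: a group of 3 heavy atoms (3 carbon; no ring) in place of a group of 11 heavy atoms (8 carbon, 2 oxygen, 1 fluorine; one six-membered non-aromatic ring with 2 hetero atoms, one six-membered aromatic ring of carbon only), on a saturated chain carbon bound to an oxygen on a saturated carbon. Going by the values given here, no measured pair exchanges a group at this position, and the step from compound 2 to compound 3 offers only a loose guide to how much a change of this size can shift the number. Among the compounds with values here, because compound 1 gives 1.5 nM with a group in place that is far larger than the isopropyl that enters, while no measured compound shows what the shared core achieves with so small a side chain, a loss of potency is expected for compound 4, of roughly the size of a 20-fold higher number from compound 1 to compound 4 (1.30 log units; beyond the scatter). Compound 4 is therefore estimated to give about 30 nM in this assay, with a plausible range from 6 nM to 150 nM.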

Compound 4, half-maximal effective concentration: 4 nM
For compound 4 the middle estimate is 7.5-fold (0.88 log units) above the measured one; measured number outside the range, below it.
By their numbers in this assay, from the lowest: compounds 1, 3 and 4 (each within the scatter of the next, the first and the last beyond it); then compound 2.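

In this assay the large ether side chain of compound 1 proves not to be essential for a low number: isopropyl, with 3 heavy atoms, replaces a group of 11 heavy atoms and removes both of its rings, yet the cost is only modest (a 2.7-fold higher number from compound 1 to compound 4 (0.43 log units; beyond the scatter)). On the saturated ring carbon, isobutoxy cannot be told apart from the amide-linked group of compound 3 (a 1.3-fold higher number from compound 3 to compound 4 (0.12 log units; within the scatter)), while it gives a modestly lower number than the 2-chloro-4-fluorophenyl group of compound 2 (a 2.3-fold lower number from compound 2 to compound 4 (0.35 log units; beyond the scatter)). Nothing available accounts for how well so small a side chain performs.

The compounds shown leave open how far this side chain can shrink or grow before the number moves further, for example with a plain methoxy group, a free hydroxyl or a longer chain such as n-hexyloxy. They also leave open which part of the large group in compound 1 supplies the modest gain over isopropyl, which a simple benzyl ether without the fluorine and the oxygen-containing ring could help to separate.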